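The compounds below may be only part of what the source reports. "The series", "measured", "known", "first", "only" and "open" are said of these compounds alone.

In a functional assay on HL-60 cells (Homo sapiens) for antiproliferative activity, read by MTT assay, with a stated time of 72 h (on this read-out higher numbers stand for weaker inhibition and lower numbers for stronger inhibition), compound 1 `COc1ccc(-c2c(C(=O)c3cc(OC)c(OC)c(OC)c3)sc3ccccc23)cc1` gives 1600 nM. Compound 2 `COc1ccc(-c2c(C(=O)c3cc(OC)c(OC)c(OC)c3)sc3ccccc23)cc1C` gives > 10000 nM, which is a limit of the assay and not a number; this is the limit of > 10000 nM in this assay, at which 1 of the 2 values shown sits. Among the measured compounds shown here, the one measured step, an at least 6.2-fold higher number from compound 1 to compound 2 (0.79 log units; beyond the scatter), is methyl in place of hydrogen on an aromatic carbon and lies beyond the scatter. The change to compound 3 `COc1cc(C(=O)c2sc3ccccc3c2Nc2ccc(Cl)cc2)cc(OC)c1OC` is (4-chlorophenyl)amino in place of 4-methoxy-3-methylphenyl on an aromatic carbon. For the measured compounds named here, no measured step covers this exchange directly. The 4-methoxy-3-methylphenyl leaves, and compound 1, without that methyl, gives 1600 nM, so a lower number is expected in this assay. The expected step is an at least 5.0-fold lower number from compound 2 to compound 3 (0.69 log units; beyond the scatter). For compound 3 the estimated value is 2000 nM, with an expected range of 300 nM to 10000 nM.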

Compound 3, half-maximal inhibitory concentration: 5400 nM
The estimate for compound 3 lay 2.7-fold (0.43 log units) below the measured number; low and high end bracket the measured number.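

In this assay, (4-chlorophenyl)amino at this position still gives a measured number, but replacing 4-methoxyphenyl with it gives a 3.4-fold higher number from compound 1 to compound 3 (0.53 log units; beyond the scatter). Replacing 4-methoxy-3-methylphenyl with it gives an at least 1.8-fold lower number from compound 2 to compound 3 (0.26 log units; that floor lies within the scatter), so no gain over compound 2 is established. The value of compound 2 is a limit of the assay and not a number: the limit of > 10000 nM in this assay, at which 1 of the 3 values shown sits.

The exchange alters the link to the ring and the ring substituent together, and the compounds shown do not separate the two. Also open, from the compounds shown here alone, is how a morpholine or a carboxylic acid would read at this position.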